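The source may hold more compounds than are shown below. What is called first, only, known or untested is meant among the compounds shown, and "the series" means these compounds.

Measured compounds:
- compound 1 `COc1cc(-c2nn(-c3cccc(NC(=O)Nc4cc(C(F)(F)F)cc(C(F)(F)F)c4)c3)cc2-c2ccncc2)ccc1Cl` in a functional assay on HCT-15 cells (Homo sapiens) for inhibition, read by sulforhodamine B assay, with a stated time of 48 h (on this read-out lower numbers stand for higher toxicity in this test and higher numbers for lower toxicity in this test), gives 4330 nM
- compound 2 `COc1cc(-c2nn(-c3cccc(NC(=O)c4cccc(C(F)(F)F)c4)c3)cc2-c2ccncc2)ccc1Cl` in this assay gives only a limit, > 50000 nM

Compound 2 stands at a limit of the test, not at a number; its entry sits at the limit of > 50000 nM in this assay, at which 1 of the 2 values shown sits. Compound 1 gives a number, 4330 nM, so it is the only measured point with a real value in this series.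

Compound 3 `COc1cc(-c2nn(-c3cccc(NC(=O)Nc4ccc(Cl)c(C(F)(F)F)c4)c3)cc2-c2ccncc2)ccc1Cl` differs from compound 2 by (4-chloro-3-(trifluoromethyl)phenyl)amino in place of 3-(trifluoromethyl)phenyl on a carbonyl carbon. Among the compounds with values here, no step between two measured compounds is available, so the size of this change cannot be read from a measured pair. In build, compound 3 comes to resemble compound 1 more than compound 2 does, and the value of compound 1, 4330 nM, is taken as the nearest guide.

A step beyond the scatter, toward higher toxicity, is expected for compound 3, an at least 10-fold lower number from compound 2 to compound 3 (1.00 log units; beyond the scatter). Compound 3 is estimated at 5000 nM, with a range from 1500 nM to 25000 nM.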

Compound 3, concentration lethal to 50% of the cells: > 32500 nM
Compound 3 ended at the assay's limit; the forecaster's own chance of this, stated with the estimate: 15%; at least 6.5-fold (0.81 log units) between middle value and limit.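

In this assay compound 2 gives > 50000 nM, a limit and not a number. Compound 3 gives > 32500 nM, likewise a limit, so no step can be read between these two compounds. From the compounds shown here alone, whether (4-chloro-3-(trifluoromethyl)phenyl)amino in place of 3-(trifluoromethyl)phenyl on a carbonyl carbon changes the read-out at all stays open.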